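This account rests on a few compounds, and the source may have more. Where it says the series, first, only, none or still open, it means among the compounds named here.

Measured compounds in a functional assay on MOLT-4 cells (Homo sapiens) for antiproliferative activity; a higher number here means a weaker inhibitor, a lower number a stronger inhibitor:
compound 1 `COc1ccc(-c2cc(N)c(C(=O)c3cc(OC)c(OC)c(OC)c3)s2)cc1OC` gives 20 nM
compound 2 `COc1cc(C(=O)c2sc(-c3cccc([N+](=O)[O-])c3)cc2N)cc(OC)c1OC` gives 7.5 nM
compound 3 `COc1cc(C(=O)c2sc(-c3ccccc3Cl)cc2N)cc(OC)c1OC` gives 17 nM

Compound 1 carries the highest number of the three; its gap to compound 3 lies within the scatter, while compound 2 sits a modest step lower. Three aryl groups on the shared core have been compared so far: a 2.7-fold lower number from compound 1 to compound 2 (0.43 log units; beyond the scatter), a 1.2-fold lower number from compound 1 to compound 3 (0.07 log units; within the scatter), and a 2.3-fold higher number from compound 2 to compound 3 (0.36 log units; beyond the scatter).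

Compound 4 `COc1cc(C(=O)c2sc(-c3ccc(C)cc3)cc2N)cc(OC)c1OC` is not yet measured. Relative to compound 1 it differs in one place: 4-methylphenyl in place of 3,4-dimethoxyphenyl on an aromatic carbon. The two measured steps that bear on this exchange are the two other replacements of the same 3,4-dimethoxyphenyl group, one modest in the lower direction and one within the scatter. Neither is large, so the 4-methylphenyl exchange is expected to leave the number near that of compound 1 or somewhat lower, and a step clearly beyond the scatter is not expected. The estimate for compound 4 in this assay is 15 nM, with a range from 5 nM to 50 nM. This estimate corresponds to an expected step of a 1.3-fold lower number from compound 1 to compound 4 (0.12 log units; within the scatter), within or near the scatter.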

Compound 4, half-maximal inhibitory concentration: 16 nM
Beside the measured number, compound 4's estimate is 1.1-fold (0.03 log units) below it, within the range that was stated.
By their numbers in this assay, from the lowest: compound 2; then compounds 4, 3 and 1 (each within the scatter of the next).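

In this assay, putting 4-methylphenyl on this aromatic carbon next to the ring sulfur gives a 1.3-fold lower number from compound 1 to compound 4 (0.10 log units; within the scatter) and also a 1.1-fold lower number from compound 3 to compound 4 (0.03 log units; within the scatter) in place of 2-chlorophenyl, so an aryl group with no hydrogen-bond acceptors and fewer heavy atoms than 3,4-dimethoxyphenyl shows no change beyond the scatter. Set against 3-nitrophenyl, the same group gives a 2.1-fold higher number from compound 2 to compound 4 (0.33 log units; beyond the scatter) and, with three different aryl groups now lying within the scatter of one another, compound 2 alone stands apart. Nothing available explains this separation.

As far as these compounds go, it remains open whether an aryl group bearing an amine or a carboxylic acid would stay within this narrow band. A longer alkyl chain in place of the aryl ring is equally untested by the compounds shown.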